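Swapping Bromo for Nitro in a Cytotoxicity Series

The source may hold more compounds than are shown below. What is called first, only, known or untested is meant among the compounds shown, and "the series" means these compounds.

Three compounds from one series have been run in a toxicity assay on NIH3T3 cells (Mus musculus) for cytotoxicity, read by resazurin assay; a higher number here means that more compound is needed for the effect, a lower number that less compound is needed. Compound 1 `O=C(OC1CCCCC1)c1ccc(NCc2cncn2Cc2ccc(-c3ccccc3)cc2)cc1-c1ccccc1` reaches only a limit of the assay, recorded as > 10000 nM. Compound 3 `c1ccc(-c2ccc(Cn3cncc3CNc3ccc(-c4ccccc4)cc3)cc2)cc1` also stops at a limit, recorded as > 10000 nM. Among the compounds with values here, compound 2 `COC(=O)c1ccc(NCc2cncn2Cc2ccccc2Br)cc1-c1ccccc1` is the sole member that yields an actual number in this assay, 10000 nM, a value that coincides with the limit of > 10000 nM in this assay, at which 2 of the 3 values shown sit. Compound 4 `COC(=O)c1ccc(NCc2cncn2Cc2ccccc2[N+](=O)[O-])cc1-c1ccccc1` differs from compound 2 by nitro in place of bromo on an aromatic carbon, a change from 2-bromophenyl to 2-nitrophenyl at a position ortho to a large group. Within the data shown here, no measured pair shows how such a swap moves the read-out in this assay, so no step beyond the usual scatter is expected. Compound 4 is estimated at 10000 nM, within a range from 5000 nM to 20000 nM. The step from compound 2 to compound 4 is expected to be no change at the digits printed from compound 2 to compound 4 (within the scatter).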

Compound 4, half-maximal effective concentration: 10000 nM
The estimate for compound 4 equals the measured number at the digits printed; the range from low to high includes it.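

In this assay, within the data shown here, nitro in place of bromo on this aromatic carbon, ortho to a large group, gives the first reading of any change at this position: no change at the digits printed from compound 2 to compound 4 (within the scatter). The series therefore now holds two compounds with a real number, and either group at this position gives the same value. That number offers little room for a rise, as it coincides with a ceiling: the limit of > 10000 nM in this assay, at which 2 of the 4 values shown sit. The compounds shown leave open whether an amine or a carboxylic acid at this position would give a lower number.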